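The compounds below may be only part of what the source reports. "The series", "measured", "known", "first", "only" and "open" are said of these compounds alone.

Compound 2 `Cc1ccc(C(=O)O)cc1OCCCCOc1ccc(C(=O)CC2CCCC2)c(O)c1C` stands highest of the two numbers in hand: in an assay on HEK293 cells for positive allosteric modulation of metabotropic glutamate receptor 2 (Rattus norvegicus), read by thallium flux, with a stated time of 2.5 min (on this read-out lower numbers stand for an effect already at smaller amounts and higher numbers for an effect only at larger amounts of compound), compound 2 gives 1290 nM, while compound 1 `Cc1c(OCCCCOc2ccc(C(=O)O)cc2Cl)ccc(C(=O)CC2CCCC2)c1O` gives 237 nM. Compound 3 `Cc1cc(OCCCCOc2ccc(C(=O)CC3CCCC3)c(O)c2C)ccc1C(=O)O` differs from compound 2 by 4-carboxy-3-methylphenyl in place of 5-carboxy-2-methylphenyl on an oxygen on a saturated carbon. Within the data shown here, the one measured step bearing on this, a 5.4-fold higher number from compound 1 to compound 2 (0.74 log units; beyond the scatter), replaced a 4-carboxy-2-chlorophenyl group with the 5-carboxy-2-methylphenyl group; compound 3 again carries a 4-carboxy group, so a lower number is expected, though the methyl differs from the chlorine of compound 1. Compound 3 is therefore estimated at 400 nM (range 150 nM to 1200 nM), an expected step of a 3.2-fold lower number from compound 2 to compound 3 (0.51 log units; beyond the scatter).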

Compound 3, half-maximal effective concentration: 564 nM
The estimate for compound 3 lay 1.4-fold (0.15 log units) below the measured number; low and high end bracket the measured number.
By their numbers in this assay, from the lowest: compound 1; then compound 3; then compound 2.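

With the same atoms joined differently, a 2.3-fold lower number from compound 2 to compound 3 (0.36 log units; beyond the scatter) shows that the placing of carboxy and methyl on this ring moves the number by itself. Going to 4-carboxy-3-methylphenyl from 4-carboxy-2-chlorophenyl still leaves a 2.4-fold higher number from compound 1 to compound 3 (0.38 log units; beyond the scatter) as a gap, so keeping the 4-carboxy group does not alone restore the number of compound 1. Nothing measured here explains either step.
Still open, as far as these compounds go, is whether the chlorine itself or its place on the ring accounts for that gap. Also open, from the compounds shown here alone, is how an unsubstituted 4-carboxyphenyl group, or a tetrazole in place of the carboxylic acid, would read.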